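The source may report more compounds than this note shows. Statements on the series, on what has been measured and on what is new or still open speak of the compounds shown alone.

In an assay on isolated protein for displacement of a labelled ligand from metabotropic glutamate receptor 5 (Homo sapiens), with a stated time of 60 min, tested at 1 uM (on this read-out lower numbers stand for less inhibition and higher numbers for more inhibition at the one concentration tested (going by the name of the read-out)), the three measured compounds give these numbers:
compound 1, `CC1CCN(c2c(S(=O)(=O)c3cc(F)cc(F)c3)cnc3cc(Cl)ccc23)CC1`, 94%
compound 2, `CC1CCN(c2c(S(=O)(=O)c3cc(Cl)cc(Cl)c3)cnc3cc(Cl)ccc23)CC1`, 93%
compound 3, `Cc1ccc(S(=O)(=O)c2cnc3cc(Cl)ccc3c2N2CCC(C)CC2)cc1Cl`, 89%

Compound 3 holds the lowest of the three numbers, but only narrowly: the nearest is compound 2, with a number 4 percentage points lower from compound 2 to compound 3 (within the scatter), and the furthest is compound 1, with a number 5 percentage points lower from compound 1 to compound 3 (within the scatter), so all three sit within the usual scatter of one another. The three compounds share one core and differ only in the aromatic ring carried on the sulfonyl sulfur.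

Compound 4, `CC1CCN(c2c(S(=O)(=O)c3ccc(C#N)cc3)cnc3cc(Cl)ccc23)CC1`, keeps that core and again changes this ring: 4-cyanophenyl in place of 3-chloro-4-methylphenyl on a sulfonyl sulfur. Among the measured compounds shown here, the steps that bear on it are the three exchanges of the same ring among the measured compounds: a number 1 percentage points lower from compound 1 to compound 2 (within the scatter), a number 5 percentage points lower from compound 1 to compound 3 (within the scatter) and a number 4 percentage points lower from compound 2 to compound 3 (within the scatter), each within the scatter. All of those rings carried halogens and no hydrogen-bond acceptor; a 4-cyanophenyl has not been tried, so the precedent is thinner. The expectation is therefore a modest loss at most, a number 9 percentage points lower from compound 3 to compound 4 (within the scatter), with a wide range to allow for the new group. Compound 4 is estimated at 80%, between 55% and 95%.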

Compound 4, a percentage reported as inhibition, at one concentration (the size of the read-out at that concentration, not a potency): 70%
Beside the measured number, compound 4's estimate is 10 percentage points above it; the range from low to high includes it.
By their numbers in this assay, from the lowest: compound 4; then compounds 3, 2 and 1 (each within the scatter of the next).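

In this assay, the ring on the sulfonyl sulfur proves not to be freely exchangeable: the change to 4-cyanophenyl gives a number 19 percentage points lower from compound 3 to compound 4 (beyond the scatter), and the comparisons with the other two rings give a number 23 percentage points lower from compound 2 to compound 4 (beyond the scatter) and a number 24 percentage points lower from compound 1 to compound 4 (beyond the scatter), whereas every exchange among the three earlier rings stayed within the scatter. The step from the 3-chloro-4-methylphenyl ring keeps the heavy-atom count unchanged, so that count alone does not separate the two rings; what differs is that chlorine and methyl leave while a nitrile, with its hydrogen-bond acceptor, enters. No measurement at hand explains why this exchange lowers the number.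

On these data alone, it remains open whether the drop follows the arrival of the nitrile or the departure of the chlorine and methyl, a question that a plain phenyl ring, or a ring carrying an amide or a carboxylic acid in place of the nitrile, could help to settle. As far as these compounds go, each figure also comes from a single concentration, so how far these steps would translate into a difference in potency is unknown.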